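Extending the Amine Side Chain of Compound 1

The source may hold more compounds than are shown below. What is called first, only, known or untested is meant among the compounds shown, and "the series" means these compounds.

Compound 1, `CN(C)CCNc1ccnc2cc(OCc3ccc(F)cc3)ccc12`: 580 nM
Compound 2, `CN(C)CCNc1ccnc2cc(OCc3ccccc3)ccc12`: 2350 nM
Compound 3, `C=CCOc1ccc2c(NCCN(C)C)ccnc2c1`: 1270 nM

In a functional assay on RKO cells (Homo sapiens) for cytotoxicity, read by MTT assay, with a stated time of 48 h (a higher number here means a weaker inhibitor, a lower number a stronger inhibitor), compound 1 holds the lowest of the three measured numbers; the steps of a 2.2-fold higher number from compound 1 to compound 3 (0.34 log units; beyond the scatter) and a 4.1-fold higher number from compound 1 to compound 2 (0.61 log units; beyond the scatter) both lead away from it to higher numbers. Compound 4, `CN(C)CCCNc1ccnc2cc(OCc3ccc(F)cc3)ccc12`, differs from compound 1 by (dimethylamino)methyl in place of dimethylamino on a saturated chain carbon, two bonds along the chain from a nitrogen on an aromatic ring. Going by the values given here, the two measured steps both concern the benzyloxy end of the shared core, not the amine chain, so no measured step bears directly on this change. The expectation therefore rests on compound 1 alone, and a step of a 1.2-fold higher number from compound 1 to compound 4 (0.08 log units; within the scatter) is expected, meaning no movement beyond the scatter. Compound 4 is estimated at 700 nM, with a range from 300 nM to 1600 nM.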

Compound 4, half-maximal inhibitory concentration: 1230 nM
For compound 4 the middle estimate is 1.8-fold (0.24 log units) below the measured one; measured number inside the range.
By their numbers in this assay, from the lowest: compound 1; then compounds 4, 3 and 2 (each within the scatter of the next).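

In this assay, lengthening the amine side chain from (2-(dimethylamino)ethyl)amino to (3-(dimethylamino)propyl)amino gives a 2.1-fold higher number from compound 1 to compound 4 (0.33 log units; beyond the scatter), the only step shown on this end of the molecule. The chain length therefore matters here, at least for this pair, although the step is modest. Nothing shown explains why the number rises. Still open, on these data alone, is how a longer chain, such as 4-(dimethylamino)butyl, or a ring amine such as morpholine in place of dimethylamino, would read. As far as these compounds go, the same lengthening on compound 2 also remains open.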